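Aryl swap on a shared core: nitro to bromo

This account rests on a few compounds, and the source may have more. Where it says the series, first, only, none or still open, it means among the compounds named here.

Measured so far:
compound 1: `CC(c1ccc(-c2ccccc2)c(F)c1)c1nnc2n1N=C(c1ccc(Cl)cc1Cl)CS2`, 5400 nM
compound 2: `CC(c1ccc(-c2ccccc2)c(F)c1)c1nnc2n1N=C(c1ccc([N+](=O)[O-])cc1)CS2`, 3500 nM

Of the compounds shown here, two on a shared core have been tested in a functional assay on FOCUS cells (Homo sapiens) for inhibition, read by sulforhodamine B assay, with a stated time of 72 h; a higher number here means a weaker inhibitor, a lower number a stronger inhibitor. Compound 1 `CC(c1ccc(-c2ccccc2)c(F)c1)c1nnc2n1N=C(c1ccc(Cl)cc1Cl)CS2` gives 5400 nM, and compound 2 `CC(c1ccc(-c2ccccc2)c(F)c1)c1nnc2n1N=C(c1ccc([N+](=O)[O-])cc1)CS2` gives 3500 nM. Compound 2 holds the lowest of the two numbers, yet the step of a 1.5-fold lower number from compound 1 to compound 2 (0.19 log units; within the scatter) lies within the scatter, so no order between the two can be claimed.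

Compound 3 `CC(c1ccc(-c2ccccc2)c(F)c1)c1nnc2n1N=C(c1ccc(Br)cc1)CS2` has not yet been measured. It differs from compound 2 in one place: bromo in place of nitro on an aromatic carbon. Among the measured compounds shown here, the only measured step that bears on this change is a 1.5-fold lower number from compound 1 to compound 2 (0.19 log units; within the scatter), an exchange of the same aryl group on the same carbon, and it stayed within the scatter. For the measured compounds named here, with a single within-scatter step as the sole guide, no change beyond the scatter is expected in this assay in either direction. Compound 3 is therefore estimated at 4000 nM, ranging from 1500 nM to 11000 nM, which corresponds to an expected step of a 1.1-fold higher number from compound 2 to compound 3 (0.06 log units; within the scatter).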

Compound 3, half-maximal inhibitory concentration: 8500 nM
Compound 3: middle estimate off by 2.1-fold (0.33 log units), on the low side; the measured number falls inside the stated range.
By their numbers in this assay, from the lowest: compounds 2, 1 and 3 (each within the scatter of the next, the first and the last beyond it).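

In this assay, the aryl exchange gives its first step beyond the scatter: bromo in place of nitro, on an aromatic carbon para to a large group, gives a 2.4-fold higher number from compound 2 to compound 3 (0.39 log units; beyond the scatter), a modest change. The 4-bromophenyl and 2,4-dichlorophenyl groups cannot be told apart, with a 1.6-fold higher number from compound 1 to compound 3 (0.20 log units; within the scatter), so compound 1 cannot be ordered against either of the other two compounds and only the two ends of this short series separate. No available evidence accounts for the difference between nitro and bromo at this position.

As far as these compounds go, whether nitro or bromo is the unusual member remains open, since three aryl groups give no trend. An amine, a nitrile or a carboxylic acid on the same aromatic carbon would show how far numbers at this position can move in either direction.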